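The compounds below may be only part of what the source reports. "The series", "measured", "known", "first", "only" and "open" are said of these compounds alone.

Working notes on the series in a toxicity assay on HFF-1 cells (Homo sapiens) for cytotoxicity, read by WST assay, with a stated time of 72 h; on this read-out higher numbers stand for weaker inhibition and lower numbers for stronger inhibition. Compound 1 (`CCN(CC)CC#CCSc1nc2c(c(=O)[nH]c(=O)n2C)n1C`) gives 3680 nM and compound 3 (`Cn1cnc2nc(SCC#CCN3CCCCC3)nc(SCC#CCN3CCCCC3)c21`) gives 3980 nM, so these two values lie within the scatter of each other. Compound 2 (`CCN(CC)CC#CCSc1nc(Cl)nc2nc(SCC#CCN(CC)CC)n(C)c12`) gives 1000 nM, a lower number than either of the other two, and its gap to compound 1 lies beyond the scatter.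

The next compound to read is compound 4 (`Cn1c(SCC#CCN2CCCC2)nc2c1c(=O)[nH]c(=O)n2C`), which has pyrrolidin-1-yl in place of diethylamino on a saturated chain carbon bound to a triple-bonded carbon. Going by the values given here, no pair of measured compounds differs in this one place alone, so the series offers no direct precedent for the change. The expectation therefore stays anchored on compound 1 at 3680 nM. In this assay no change beyond the scatter is expected, and the estimated step of a 1.1-fold higher number from compound 1 to compound 4 (0.04 log units; within the scatter) is correspondingly small. For compound 4 the expected value is 4000 nM, with an estimated range of 1800 nM to 9000 nM.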

Compound 4, half-maximal inhibitory concentration: 34300 nM
For compound 4 the middle estimate is 8.6-fold (0.93 log units) below the measured one; measured number outside the range, above it.
By their numbers in this assay, from the lowest: compound 2; then compounds 1 and 3 (each within the scatter of the next); then compound 4.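

In this assay, going by these compounds alone, pyrrolidin-1-yl in place of diethylamino on a saturated chain carbon bound to a triple-bonded carbon gives a 9.3-fold higher number from compound 1 to compound 4 (0.97 log units; beyond the scatter), the first single-place step and one toward weaker inhibition. The two groups match in heavy atoms, carbon, nitrogen, hydrogen-bond donors, hydrogen-bond acceptors and net charge, and differ in the five-membered non-aromatic ring, so at this position a change that leaves those counts untouched can still move the number beyond the scatter. No measurement at hand accounts for this step.

This single pair leaves open whether the step comes from the ring itself or is particular to pyrrolidin-1-yl. How morpholin-4-yl or dimethylamino would read at the same place on the core of compound 1 remains an open question.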